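The source may hold more compounds than are shown below. What is called first, only, known or untested is meant among the compounds shown, and "the series" means these compounds.

Measured compounds: compound 1 `Cc1ccc(Nc2nc(Cl)nc3c2ncn3Cc2ccc(C(=O)Nc3ccccc3N)cc2)cc1` with 81.5%; compound 2 `Cc1ccc(Nc2nc(Cl)nc3c2ncn3Cc2ccc(/C=C/C(=O)Nc3ccccc3N)cc2)cc1` with 15%.

Within the data shown here, in a functional assay on HCT-116 cells (Homo sapiens) for antiproliferative activity, read by CCK-8 assay, with a stated time of 72 h, tested at 8 uM (a lower number here means a weaker effect, a higher number a stronger effect of the compound at the concentration tested), compound 1 stands highest of the two numbers, the step of a number 66.5 percentage points lower from compound 1 to compound 2 (beyond the scatter) being the only measured comparison. Compound 3 `Nc1ccccc1NC(=O)c1ccc(Cn2cnc3c(NCc4ccccc4)nc(Cl)nc32)cc1` differs from compound 1 by benzyl in place of 4-methylphenyl on a nitrogen on an aromatic ring. Among the measured compounds shown here, the one measured step changes the linker to the aminophenyl amide, not the amine on the core, so no measured step bears on this change and the direction is open. Without guidance, a moderate step of a number 21.5 percentage points lower from compound 1 to compound 3 (beyond the scatter) downward is expected for compound 3. Compound 3 is therefore estimated at 60%, within 25% to 90%.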

Compound 3, a percentage reported as inhibition, at one concentration (the size of the read-out at that concentration, not a potency): 78.4%
Compound 3: the middle estimate sits 18.4 percentage points below what was measured, within the range that was stated.
By their numbers in this assay, from the lowest: compound 2; then compounds 3 and 1 (each within the scatter of the next).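

In this assay, the step of a number 3.1 percentage points lower from compound 1 to compound 3 (within the scatter) shows that on this nitrogen benzyl can stand in place of 4-methylphenyl with no change beyond the scatter, unlike the large step seen earlier at the linker. The position therefore tolerates this swap of two seven-carbon groups at the concentration tested. No available evidence accounts for this result.

Going by these compounds, whether a methyl, a longer chain such as 2-phenylethyl, or a phenyl ring bearing a carboxylic acid would read the same on this nitrogen stays open. One concentration also leaves open whether compound 1 and compound 3 match in potency.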